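This account rests on a few compounds, and the source may have more. Where it says the series, first, only, none or still open, it means among the compounds named here.

Measured so far:
Compound 1, `COc1cc(/C=C/C(=O)/C=C/c2ccco2)ccc1OCc1cn(CCCCOc2cc(=O)oc3ccccc23)nn1`: 43%
Compound 2, `COc1ccccc1/C=C/C(=O)/C=C/c1ccc(OCc2cn(CCCCOc3cc(=O)oc4ccccc34)nn2)c(OC)c1`: 47%
Compound 3, `COc1cc(/C=C/C(=O)/C=C/c2ccco2)ccc1OCc1cn(CCOc2cc(=O)oc3ccccc23)nn1`: 68%

All three were tested in a functional assay on COLO 205 cells (Homo sapiens) for inhibition, read by sulforhodamine B assay, with a stated time of 48 h, tested at 50 uM; on this read-out higher numbers stand for more inhibition of growth at the one concentration tested and lower numbers for less inhibition of growth. Compound 1 and compound 2 share a core and differ only by 2-methoxyphenyl in place of furan-2-yl on a double-bonded chain carbon bound to a double-bonded chain carbon; that change gave a number 4 percentage points higher from compound 1 to compound 2 (within the scatter). Compound 3 stands highest of the three, and the difference between its core and the core of compound 1 is not broken down here. Compound 4, `COc1ccccc1/C=C/C(=O)/C=C/c1ccc(OCc2cn(CCOc3cc(=O)oc4ccccc34)nn2)c(OC)c1`, has not yet been measured; it carries the same change on the core of compound 3, namely (2-methoxyphenyl in place of furan-2-yl on a double-bonded chain carbon bound to a double-bonded chain carbon). Because the step of a number 4 percentage points higher from compound 1 to compound 2 (within the scatter) stayed within the scatter, the step from compound 3 to compound 4 is expected to be small as well, estimated as a number 2 percentage points higher from compound 3 to compound 4 (within the scatter). Compound 4 is therefore estimated at 70% in this assay, with a likely range from 56% to 82%.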

Compound 4, percent growth inhibition at one concentration: 67%
Estimate against measurement, compound 4: 3 percentage points above, and the stated range covers the measured number.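

In this assay, 2-methoxyphenyl in place of furan-2-yl gave a number 1 percentage points lower from compound 3 to compound 4 (within the scatter). Set beside the earlier step, the change carried from one core to the other with no difference that can be told apart: the same change on two cores in this assay, a number 4 percentage points higher (within the scatter) from compound 1 to compound 2 and a number 1 percentage points lower (within the scatter) from compound 3 to compound 4, 5 percentage points apart, within the scatter of two such steps. This shows that the change stayed within the scatter on both of these cores at the one concentration tested, but two pairs do not show that it would do so on any other core, nor that the two groups match at other concentrations.

The compounds shown hold only furan-2-yl and 2-methoxyphenyl at this place. Going by these compounds, it remains open how a phenyl ring carrying an amine or a carboxylic acid would behave there, and whether the match holds in other cell lines.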